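A few compounds are considered here, and "the series" means these few. Any claim that something is new, unique, unknown or untested is made for them only; others in the source may bear on it.

Compound 3, `Nc1cc(N)c2nc(-c3ccccc3)c(NCc3ccc(F)cc3)nc2c1`, carries a (4-fluorobenzyl)amino group on the shared core. In a functional assay on HOP-62 cells (Homo sapiens) for inhibition, read by sulforhodamine B assay, with a stated time of 48 h (a lower number here means a stronger inhibitor of growth, a higher number a weaker inhibitor of growth), compound 3 gives only a limit, < 100000 nM. Its neighbour compound 1, `Nc1cc(N)c2nc(-c3ccccc3)c(NCc3ccc(Cl)c(Cl)c3)nc2c1`, gives 31600 nM, and compound 2, `CCOC(=O)[C@H](CCC(=O)O)NC(=O)c1ccc(Sc2nc3cc(N)cc(N)c3nc2-c2ccccc2)cc1`, which joins its side chain to the core through a sulfur atom, gives 85100 nM. The step that the limit leaves unreadable from compound 1 to compound 3 cannot be read, since compound 3 sits at the limit (the limit of < 100000 nM in this assay, at which 1 of the 3 values shown sits). Compound 4, `Nc1cc(N)c2nc(-c3ccccc3)c(Sc3ccc(F)cc3)nc2c1`, differs from compound 3 by (4-fluorophenyl)sulfanyl in place of (4-fluorobenzyl)amino on an aromatic carbon, placed on an aromatic carbon next to the ring nitrogen. Among the measured compounds shown here, no measured step covers this exchange, so the expectation for the step that the limit leaves unreadable from compound 3 to compound 4 is only a loose one. Compound 4 is estimated at 50000 nM, in a range from 15000 nM to 150000 nM.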

Compound 4, concentration for total growth inhibition: 34700 nM
Beside the measured number, compound 4's estimate is 1.4-fold (0.16 log units) above it; measured number inside the range.
By their numbers in this assay, from the lowest: compounds 1 and 4 (each within the scatter of the next); then compound 2.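

No step can be read between compound 3 and compound 4, because compound 3 gives only a limit and not a number: the limit of < 100000 nM in this assay, at which 1 of the 4 values shown sits.

On these data alone, whether (4-fluorophenyl)sulfanyl in place of (4-fluorobenzyl)amino strengthens or weakens growth inhibition in this assay stays open.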